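The source may hold more compounds than are shown below. What is called first, only, known or untested is meant among the compounds shown, and "the series" means these compounds.

Working notes on a small set of pentafluorophenyl sulfonamides. Compound 1 `O=S(=O)(Nc1ccc2[nH]ccc2c1)c1c(F)c(F)c(F)c(F)c1F` carries the sulfonamide on an indole core, while compound 2 `CN(C)c1ccc(NS(=O)(=O)c2c(F)c(F)c(F)c(F)c2F)cc1` carries it on a dimethylamino-substituted benzene; both are characterised in a functional assay on SF-295 cells (Homo sapiens) for inhibition; on this read-out higher numbers stand for weaker inhibition of growth and lower numbers for stronger inhibition of growth. In this assay compound 1 gives 40 nM and compound 2 gives 501 nM. Among the measured compounds shown here, compound 2 thus stands at the highest of the two numbers so far; the gap to compound 1 lies beyond the usual scatter, so compound 2 is the weaker of the two on this read-out.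

For the measured compounds named here, the next compound, compound 3 `COc1ccc(NS(=O)(=O)c2c(F)c(F)c(F)c(F)c2F)cc1`, keeps the pentafluorophenyl sulfonamide and the benzene core of compound 2 and changes only one group: methoxy in place of dimethylamino on an aromatic carbon. The group that leaves and the group that enters are both small, uncharged and each counts one hydrogen-bond acceptor, and they sit at the same aromatic carbon, para to the large group. Going by the values given here, no measured pair in this set shows such a change, so the direction is open; the step from compound 2 to compound 3 is expected to be small, a 1.1-fold lower number from compound 2 to compound 3 (0.05 log units; within the scatter), most likely within the scatter. Compound 3 is therefore estimated at 450 nM, with a range from 150 nM to 1400 nM.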

Compound 3, concentration for 50% growth inhibition: 11 nM
For compound 3 the middle estimate is 41-fold (1.61 log units) above the measured one, and the stated range ends above it.
By their numbers in this assay, from the lowest: compound 3; then compound 1; then compound 2.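

Among the compounds shown here, the exchange of dimethylamino for methoxy on an aromatic carbon, para to a large group, is the first one-place change, and in this assay it gives a 46-fold lower number from compound 2 to compound 3 (1.66 log units; beyond the scatter), so the group at this position is far from indifferent for growth inhibition. The size of the step does not follow from the counted features: both groups have no ring, no net charge, no hydrogen-bond donors and one hydrogen-bond acceptor, and they differ only in heavy-atom count and in carrying nitrogen or oxygen. No supporting measurement is available to explain the step.

As far as these compounds go, with a single exchange at this carbon, it remains open whether the step follows from the presence of methoxy or from the loss of dimethylamino, and a hydroxyl, a primary amine, an ethoxy or a plain methyl group at the same carbon would help separate these readings. From the compounds shown here alone, it also remains open whether the same exchange would give a step of similar size on a different core, such as that of compound 1.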